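A few compounds are considered here, and "the series" means these few. Any claim that something is new, unique, unknown or untested is made for them only; others in the source may bear on it.

Working notes on the series in a functional assay on MDA-MB-231 cells (Homo sapiens) for cytotoxicity, read by ELISA, with a stated time of 2 days; a higher number here means a weaker inhibitor, a lower number a stronger inhibitor. Compound 1 `Oc1cccc(-c2cc(-c3ccccc3)cc(-c3cccs3)n2)c1` gives 18100 nM, compound 2 `Oc1cccc(-c2cc(-c3ccccc3)cc(-c3ccncc3)n2)c1` gives 10400 nM, and compound 3 `Oc1ccc(-c2cc(-c3ccccc3)cc(-c3cccs3)n2)cc1` gives 2400 nM, the lowest of the three numbers and beyond the scatter of both others. Compound 4 `Oc1ccc(-c2cc(-c3ccccc3)cc(-c3ccc(O)cc3)n2)cc1` carries 4-hydroxyphenyl in place of thiophen-2-yl on an aromatic carbon next to the ring nitrogen: 4-hydroxyphenyl in place of thiophen-2-yl on an aromatic carbon. The closest evidence is the replacement of thiophen-2-yl by pyridin-4-yl, which gave a 1.7-fold lower number from compound 1 to compound 2 (0.24 log units; within the scatter). The other measured step, a 7.5-fold lower number from compound 1 to compound 3 (0.88 log units; beyond the scatter), changes a different group and bears only indirectly. No step beyond the scatter is therefore expected in this assay, and the expected step is a 1.3-fold higher number from compound 3 to compound 4 (0.10 log units; within the scatter). For compound 4 the estimate is 3000 nM, with an expected range of 900 nM to 10000 nM.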

Compound 4, half-maximal inhibitory concentration: 6700 nM
For compound 4 the middle estimate is 2.2-fold (0.35 log units) below the measured one; the measured number falls inside the stated range.
By their numbers in this assay, from the lowest: compound 3; then compounds 4, 2 and 1 (each within the scatter of the next, the first and the last beyond it).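

In this assay, within the data shown here, the replacement of thiophen-2-yl by 4-hydroxyphenyl gives a 2.8-fold higher number from compound 3 to compound 4 (0.45 log units; beyond the scatter) and is the first change at this position to lie beyond the scatter, while the pyridin-4-yl replacement gave a 1.7-fold lower number from compound 1 to compound 2 (0.24 log units; within the scatter) on the 3-hydroxyphenyl background. The position next to the ring nitrogen therefore responds to its substituent, and with 4-hydroxyphenyl elsewhere on the core, thiophen-2-yl gives the lower number. No measurement at hand accounts for this step. As far as these compounds go, what an amine or a carboxylic acid on the ring at this position would give remains open, as does replacing the phenyl group.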